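A few compounds are considered here, and "the series" means these few. Any claim that something is new, unique, unknown or untested is made for them only; others in the source may bear on it.

The account concerns three measured compounds and one that awaits measurement, all examined in a functional assay for inhibition of sodium/hydrogen exchanger (Oryctolagus cuniculus); a lower number here means a stronger inhibitor, a higher number a weaker inhibitor. Compound 1 `CS(=O)(=O)c1cc(C(=O)N=C(N)N)c(Cl)cc1Cl` gives 140 nM in this assay. Compound 3 `Cc1cc(Br)c(C(=O)N=C(N)N)cc1S(C)(=O)=O` gives 70 nM. Compound 2 `CCCCCc1cc(C)c(C(=O)N=C(N)N)cc1S(C)(=O)=O` gives 27 nM, the lowest of the three numbers, and its distance to compound 3 as well as to compound 1 lies beyond the usual scatter of repeated measurements, so compound 2 stands as the strongest inhibitor of the measured set.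

Compound 4 `Cc1cc(Sc2ccncc2)c(S(C)(=O)=O)cc1C(=O)N=C(N)N` is the unmeasured member. It differs from compound 2 in one place: (pyridin-4-yl)sulfanyl in place of pentyl on an aromatic carbon. No pair of measured compounds differs in just this way, so the size of the step cannot be read from a shown step; the measured values only show that the pentyl compound 2 sits below compound 3 and compound 1.

With that in mind, the step from compound 2 to compound 4 is expected to be small, a 1.5-fold higher number from compound 2 to compound 4 (0.17 log units; within the scatter), leaning towards a weaker inhibitor but probably not beyond the scatter. Compound 4 is therefore estimated at 40 nM in this assay, with a range from 12 nM to 130 nM.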

Compound 4, half-maximal inhibitory concentration: 13 nM
Estimate against measurement, compound 4: 3.1-fold (0.49 log units) above; low and high end bracket the measured number.
By their numbers in this assay, from the lowest: compound 4; then compound 2; then compounds 3 and 1 (each within the scatter of the next).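

In this assay, exchanging pentyl for (pyridin-4-yl)sulfanyl on this aromatic carbon, ortho to a methylsulfonyl group and para to a group of 6 heavy atoms, gives a 2.1-fold lower number from compound 2 to compound 4 (0.32 log units; beyond the scatter). The step is modest, yet it shows that a pentyl chain is not needed at this position for a low number, and that a six-membered aromatic ring attached through sulfur does more than merely preserve the value of the open chain. No measurement bearing on why the number falls accompanies this result.

The single step changes the ring, the sulfur link and the ring nitrogen all at once, so the compounds shown do not separate their contributions. A phenylsulfanyl group would remove only the ring nitrogen, a pyridin-4-yloxy group would replace only the sulfur, and a pyridin-2-ylsulfanyl group would move the nitrogen, while a shorter chain such as ethyl would show how the number at this position follows the length of the chain.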